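The source may report more compounds than this note shows. Statements on the series, on what has been measured and on what is new or still open speak of the compounds shown alone.

Measured in an ADME assay on HEK293 cells (Homo sapiens) for cytotoxicity, with a stated time of 6 h; a lower number here means that less compound is tolerated, a higher number that more compound is tolerated:

- Compound 1 `CCCCNc1nc(N)nc2cc(C(N)=O)ccc12` gives the limit > 18000 nM
- Compound 2 `CCCCNc1nc(N)nc2ccc(OC)cc12` gives the limit > 18000 nM
- Compound 3 `CCCCNc1nc(N)nc2cccc(OC)c12` gives the limit > 25000 nM

None of these three results is a number, and each is only a limit of the assay. Compound 3 stands at the limit of > 25000 nM in this assay, at which 1 of the 3 values shown sits. The other two stand at the limit of > 18000 nM in this assay, at which 2 of the 3 values shown sit. Among the compounds with values here, no pair of measured compounds differs in a single place, so the data offer no measured step by which to size the next change.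

Compound 4 `CCCCNc1nc(N)nc2cccc(OCc3cccnc3)c12` carries pyridin-3-yl in place of hydrogen on a saturated chain carbon bound to an oxygen on an aromatic ring, turning methoxy into (pyridin-3-yl)methoxy (pyridin-3-yl in place of hydrogen on a saturated chain carbon bound to an oxygen on an aromatic ring). The expected change in this assay is a number no higher from compound 3 to compound 4 (the limit leaves the size open), which means no expected shift in either direction beyond the usual scatter. This expectation rests on compound 3 with its limit of > 25000 nM. The estimate for compound 4 is 25000 nM, with an expected range of 10000 nM to 60000 nM.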

Compound 4, half-maximal cytotoxic concentration: > 25000 nM
Compound 4 ended at the assay's limit; the forecaster's own chance of this, stated with the estimate: 65%; the middle value lies on the limit itself.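

In this assay compound 4 gives > 25000 nM, which is a limit and not a number. Compound 3 gives > 25000 nM, also a limit. Within the data shown here, no step can therefore be read between compound 3 and compound 4. The compounds shown leave open what the half-maximal cytotoxic concentration of either compound actually is.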